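The source may hold more compounds than are shown below. What is called first, only, known or untested is meant among the compounds shown, and "the series" means these compounds.

Working notes on the series. The shared core of compound 3 `COc1cc(Cl)cc(-c2nn(-c3cccc(NC(=O)Nc4ccc(Cl)c(Cl)c4)c3)cc2-c2ccncc2)c1` is tested in a functional assay on UACC-257 cells (Homo sapiens) for inhibition, read by sulforhodamine B assay, with a stated time of 48 h, tested at 0.1 uM (on this read-out lower numbers stand for a stronger effect and higher numbers for a weaker effect at the one concentration tested), where compound 3 gives 96%. Its nearest neighbours are compound 2 `COc1cc(Cl)cc(-c2nn(-c3cccc(NC(=O)Nc4cc(C(F)(F)F)cc(C(F)(F)F)c4)c3)cc2-c2ccncc2)c1`, which in this assay gives 94%, and compound 1 `O=C(Nc1cccc(-n2cc(-c3ccncc3)c(-c3cc(O)cc(Cl)c3)n2)c1)Nc1ccc(Cl)c(Cl)c1`, which in this assay gives 91%; all three numbers lie within the scatter of one another. Within the data shown here, the one single-point step on record, a number 5 percentage points higher from compound 1 to compound 3 (within the scatter), is within the scatter.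

Compound 4 `COc1cc(Cl)cc(-c2nn(-c3cccc(NC(=O)c4cccc(C(F)(F)F)c4)c3)cc2-c2ccncc2)c1` is not yet measured. It differs from compound 3 in one place: 3-(trifluoromethyl)phenyl in place of (3,4-dichlorophenyl)amino on a carbonyl carbon. Among the measured compounds shown here, no measured step in the set bears on this change; the only step on record concerns the methyl on the oxygen, and the values of compound 2 and compound 3 show merely that exchanging the aryl on the urea nitrogen left the read-out within the scatter. With every value in the set close together and no step beyond the scatter, the expected step of a number 3 percentage points lower from compound 3 to compound 4 (within the scatter) is none beyond the scatter. For compound 4 the estimate in this assay is therefore 93%, with a range from 82% to 100%.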

Compound 4, a percentage reported as activity, at one concentration (the size of the read-out at that concentration, not a potency): 91%
Compound 4: middle estimate off by 2 percentage points, on the high side; the measured number falls inside the stated range.
By their numbers in this assay, from the lowest: compounds 1, 4, 2 and 3 (each within the scatter of the next).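

In this assay, among these compounds, the step of a number 5 percentage points lower from compound 3 to compound 4 (within the scatter) concerns the carbonyl carbon itself, whereas the earlier steps left the urea in place and touched only the aryl on the urea nitrogen or the methyl on the oxygen. Replacing (3,4-dichlorophenyl)amino with 3-(trifluoromethyl)phenyl removes the hydrogen-bond donor of the leaving group and exchanges the two chlorines for a trifluoromethyl group, and even this larger edit leaves the two values within the scatter of each other, so the urea nitrogen on this side is not shown to be needed for the read-out at this one concentration. No measurement at hand gives a reason for this result.

Still open, from the compounds shown here alone, is whether any group on this carbonyl carbon would give a step beyond the scatter, for example a morpholine amine, a benzyl group with its longer chain, or an unsubstituted phenyl. Going by these compounds, with all the numbers so close at one concentration, it also remains open whether compound 3 and compound 4 would differ in a full concentration series.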